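Urea aryl replacement at the amide nitrogen: compound 3

This account rests on a few compounds, and the source may have more. Where it says the series, first, only, none or still open, it means among the compounds named here.

Measured so far:
Compound 1 `CN(C)C1(Cc2ccccc2)CCN(c2cc(C(F)(F)F)ccc2CNC(=O)Nc2ccc(CO)c(F)c2)CC1` gives 27.9 nM in this assay.
Compound 2 `CN(C)C1(Cc2ccccc2)CCN(c2cc(C(F)(F)F)ccc2CNC(=O)Nc2cccc3c2CC(O)CC3)CC1` gives 0.95 nM in this assay.

In an assay on CHO cells for displacement of a labelled ligand from transient receptor potential cation channel subfamily V member 1 (Homo sapiens), read by scintillation counting, with a stated time of 60 min (on this read-out lower numbers stand for stronger inhibition and higher numbers for weaker inhibition), compound 2 stands lowest of the two numbers measured, with compound 1 as the only other point. Going by the values given here, the single step so far, a 29-fold lower number from compound 1 to compound 2 (1.47 log units; beyond the scatter), is large and concerns the same position, the aryl group on the amide-type nitrogen.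

Compound 3 `CN(C)C1(Cc2ccccc2)CCN(c2cc(C(F)(F)F)ccc2CNC(=O)Nc2ccc3c(c2)OCC3)CC1` differs from compound 2 by a group of 9 heavy atoms (8 carbon, 1 oxygen; one five-membered non-aromatic ring with 1 hetero atom, one six-membered aromatic ring of carbon only) in place of a group of 11 heavy atoms (10 carbon, 1 oxygen; one six-membered non-aromatic ring of carbon only, one six-membered aromatic ring of carbon only), on an amide-type nitrogen. The group that enters carries no hydrogen-bond donor, whereas the group that leaves carries one. Among the compounds with values here, no measured step covers this exact exchange; the one step available only shows that this position moves the number strongly. The expectation for compound 3 is therefore a higher number than compound 2, an 8.4-fold higher number from compound 2 to compound 3 (0.93 log units; beyond the scatter), while staying under compound 1. The estimate for compound 3 is 8 nM, with a range from 2 nM to 32 nM.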

Compound 3, inhibition constant: 41.4 nM
For compound 3 the middle estimate is 5.2-fold (0.71 log units) below the measured one; measured number above the stated range.
By their numbers in this assay, from the lowest: compound 2; then compounds 1 and 3 (each within the scatter of the next).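

In this assay, the exchange of 3-hydroxy-1,2,3,4-tetrahydronaphthalen-5-yl for the group with a five-membered non-aromatic ring holding one hetero atom gives a 44-fold higher number from compound 2 to compound 3 (1.64 log units; beyond the scatter) on the amide-type nitrogen, so two fused rings at this place do not by themselves secure the low number of compound 2. The step of a 1.5-fold higher number from compound 1 to compound 3 (0.17 log units; within the scatter) leaves these two aryl groups unseparated, although only one of them has a second ring. The exchange from compound 2 alters ring size and hydrogen-bond donor count together, and no available evidence assigns the large step to either one.

Going by these compounds, the contribution of the hydroxyl in compound 2 stays open, and the unsubstituted 1,2,3,4-tetrahydronaphthalen-5-yl group or an amine in place of that hydroxyl would address it. Also open, on these data alone, is whether the five-membered ring of compound 3 would respond to a hydroxyl on that ring.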